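The source may hold more compounds than are shown below. What is called first, only, known or untested is meant among the compounds shown, and "the series" means these compounds.

Three compounds share one core. In a functional assay on HCT-116 cells (Homo sapiens) for inhibition, read by MTT assay, with a stated time of 48 h (a lower number here means a stronger inhibitor, a higher number a weaker inhibitor), compound 1 `COc1ccc(CN(C(=O)C=C(C)C)c2cc(OC)c(OC)c(OC)c2)cc1O` gives 290 nM. In this assay compound 3 `C/C=C/C=C/C(=O)N(Cc1ccc(OC)c(O)c1)c1cc(OC)c(OC)c(OC)c1` gives 180 nM, the lowest of the two numbers, with compound 1 nearest; that step is a 1.6-fold lower number from compound 1 to compound 3 (0.21 log units; within the scatter). In this assay compound 2 `COc1cc(NCc2ccc(Br)cc2)cc(OC)c1OC` reaches only a limit, > 80000 nM, not a number. Compound 4 `COc1ccc(CN(C(=O)C(C)C)c2cc(OC)c(OC)c(OC)c2)cc1O` is not yet measured. It differs from compound 3 in one place: isopropyl in place of penta-1,3-dien-1-yl on a carbonyl carbon. Among the measured compounds shown here, only one measured step touches this carbonyl substituent, and it stayed within the scatter, so the numbers give no direct guide for an isopropyl here. For compound 4 a modest weakening is expected, a 2.8-fold higher number from compound 3 to compound 4 (0.44 log units; beyond the scatter). Compound 4 is therefore estimated at 500 nM, with a range from 150 nM to 2000 nM.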

Compound 4, half-maximal inhibitory concentration: 310 nM
The estimate for compound 4 lay 1.6-fold (0.21 log units) above the measured number; measured number inside the range.
By their numbers in this assay, from the lowest: compounds 3, 1 and 4 (each within the scatter of the next). At a limit, above all of these: compound 2.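

Compounds 1 and 3 both carry double bonds in this carbonyl substituent, whereas compound 4 shows what isopropyl, with none, does on the same carbonyl carbon: in this assay there is a 1.7-fold higher number from compound 3 to compound 4 (0.24 log units; within the scatter) and a 1.1-fold higher number from compound 1 to compound 4 (0.03 log units; within the scatter). Among these three compounds, therefore, neither the double bonds nor the longer penta-1,3-dien-1-yl chain is needed for a number of this size. Nothing shown gives a reason for this. Still open, going by these compounds, is whether methyl, a phenyl ring or a chain carrying an amine or a carboxylic acid would give similar numbers on this carbonyl carbon.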